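The source may report more compounds than this note shows. Statements on the series, on what has been measured and on what is new or still open speak of the compounds shown alone.

Three compounds share a core in which a sulfur joins a saturated chain carbon to an aromatic group. In a functional assay on A549 cells (Homo sapiens) for inhibition, read by CCK-8 assay, with a stated time of 72 h, tested at 2 uM (a higher number here means more inhibition of growth at the concentration tested, a lower number less inhibition of growth), compound 1 `Nc1ccccc1NC(=O)c1ccc(CSc2nccc(C(F)(F)F)n2)cc1` gives 75.4%, compound 2 `Nc1ccccc1NC(=O)/C=C/c1ccc(CSc2ccc(Cl)cc2)cc1` gives 55.3%, and compound 3 `Nc1ccccc1NC(=O)c1ccc(CSc2cccc(F)c2)cc1` gives 46.9%. Compound 2 thus stands second of the three: its gap to compound 3 lies within the usual scatter, while compound 1 sits beyond it at the top. Compound 4 `Nc1ccccc1NC(=O)/C=C/c1ccc(CSc2ccc(C(F)(F)F)cn2)cc1` has not yet been tested; it differs from compound 2 by 5-(trifluoromethyl)pyridin-2-yl in place of 4-chlorophenyl on a sulfur. Within the data shown here, no measured pair isolates this change, so the expectation leans on compound 1, whose 75.4% is the one value here with a trifluoromethyl group on the ring joined to the sulfur. A modest rise in this assay is expected, a number 8.7 percentage points higher from compound 2 to compound 4 (within the scatter). Compound 4 is estimated at 64%, between 46% and 82%.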

Compound 4, percent growth inhibition at one concentration: 51.7%
Estimate against measurement, compound 4: 12.3 percentage points above; the measured number falls inside the stated range.
By their numbers in this assay, from the lowest: compounds 3, 4 and 2 (each within the scatter of the next); then compound 1.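

In this assay the exchange of 4-chlorophenyl for 5-(trifluoromethyl)pyridin-2-yl on a sulfur gives a number 3.6 percentage points lower from compound 2 to compound 4 (within the scatter). This first pair to isolate a change at this position shows that the larger ring group, with its hydrogen-bond acceptor, leaves the growth inhibition indistinguishable from that of 4-chlorophenyl. No measurement at hand offers a reason for this result. From the compounds shown here alone, the ring nitrogen and the trifluoromethyl group enter together here, so their separate contributions remain open. Also open, going by these compounds, is whether an amine or a carboxylic acid on this ring would give a step beyond the scatter.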